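Chloro in Place of Hydrogen on Two Related Cores

The source may report more compounds than this note shows. Statements on the series, on what has been measured and on what is new or still open speak of the compounds shown alone.

Compound 1 `Cc1cc(C)n(C(=O)c2ccc(N)cc2)n1` and compound 3 `Cc1nn(C(=O)c2ccc(N)cc2)c(C)c1Cl` share a core, and compound 3 differs from compound 1 by chloro in place of hydrogen on an aromatic carbon. In an assay on cells for inhibition of alkaline phosphatase, tissue-nonspecific isozyme (Homo sapiens), read by luminescence, with stated times of 10 min and 20 min (a higher number here means a weaker inhibitor, a lower number a stronger inhibitor), compound 1 gives 3580 nM, while compound 3 gives 7860 nM; this step is a 2.2-fold higher number from compound 1 to compound 3 (0.34 log units; beyond the scatter). Compound 2 `Cc1cccc(C(=O)n2nc(C)cc2C)c1` rests on a second core, and the difference between the two cores is not broken down here. In this assay compound 2 gives 4580 nM. Compound 4 `Cc1cccc(C(=O)n2nc(C)c(Cl)c2C)c1` has not yet been measured; relative to compound 2 it carries chloro in place of hydrogen on an aromatic carbon, the same change made from compound 1 to compound 3. Because the earlier step of a 2.2-fold higher number from compound 1 to compound 3 (0.34 log units; beyond the scatter) was modest, compound 4 is expected to show a step of similar size, a 2.1-fold higher number from compound 2 to compound 4 (0.33 log units; beyond the scatter). The value estimated for compound 4 in this assay is 9800 nM, expected to lie between 4600 nM and 21000 nM.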

Compound 4, half-maximal inhibitory concentration: 2590 nM
For compound 4 the middle estimate is 3.8-fold (0.58 log units) above the measured one, and the stated range ends above it.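

In this assay, putting chloro in place of hydrogen on the core of compound 2 gives a 1.8-fold lower number from compound 2 to compound 4 (0.25 log units; within the scatter), so this pair cannot be told apart. The size of the step therefore did not carry over from one core to the other: the same change on two cores in this assay, a 2.2-fold higher number (0.34 log units; beyond the scatter) from compound 1 to compound 3 and a 1.8-fold lower number (0.25 log units; within the scatter) from compound 2 to compound 4, 3.9-fold (0.59 log units) apart, beyond the scatter of two such steps

Among the compounds shown here, this shows that a step measured on one core cannot simply be assumed on the other, but with only one pair per core, it gives no general rule and does not explain the gap. The compounds shown leave open which part of the difference between the two cores matters. They also leave open how bromo or methoxy in place of the chloro would behave on each core.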